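Toward a Number for a Bromo Chain Compound

A few compounds are considered here, and "the series" means these few. Any claim that something is new, unique, unknown or untested is made for them only; others in the source may bear on it.

Results in an ADME assay on MDCK cells (Canis lupus familiaris) for cytotoxicity, read by MTT assay, with a stated time of 2 days; on this read-out higher numbers stand for lower toxicity in this test and lower numbers for higher toxicity in this test:
- compound 1 `[N-]=[N+]=NCCCCc1ccc(-c2ccc(-c3ccc(-c4cccs4)s3)s2)s1` gives "not determined" (no result reported)
- compound 2 `NCCCCc1ccc(-c2ccc(-c3ccc(CCCCN)s3)s2)s1` gives 13000 nM
- compound 3 `NCCCCc1ccc(-c2ccc(-c3ccc(-c4cccs4)s3)s2)s1` gives "not determined" (no result reported)

Only one of these three entries is a number. Compound 3 has no place on the scale, since for compound 3 the record reads "not determined" (no result reported). Compound 1 shares that fate, and compound 2 alone offers a reading in this assay.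

Still to be tested is compound 4 `BrCCCc1ccc(-c2ccc(-c3ccc(-c4cccs4)s3)s2)s1`. The structural change is bromo in place of aminomethyl on a saturated chain carbon, three bonds along the chain from an aromatic carbon. In words, bromo takes the place of aminomethyl on a saturated chain carbon, three bonds along the chain from an aromatic carbon. Cut one bond further out, the same difference reads 4-aminobutyl to 3-bromopropyl.

With no value for compound 3, the size of this step cannot be read from the data, and any expectation is loosely anchored. Among the measured compounds shown here, the only reference is compound 2 at 13000 nM, and against it a modest move towards higher numbers in this assay is expected, possibly no larger than the usual scatter. The estimate for compound 4 is 20000 nM, with an expected range of 4000 nM to 100000 nM.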

Compound 4, half-maximal cytotoxic concentration: > 200000 nM
Compound 4: a limit, no number; the forecaster's own chance of this, stated with the estimate: 30%; at least 10-fold (1.00 log units) between middle value and limit.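

In this assay compound 4 gives > 200000 nM, a limit of the assay and not a number. Compound 3 carries no number in this test either, so no step can be read between compound 3 and compound 4. The compounds shown leave open what the change from 4-aminobutyl to 3-bromopropyl does on its own to this reading.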